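The compounds below may be only part of what the source reports. "The series", "measured", "known", "first", "only" and "open" are said of these compounds alone.

In a functional assay on HeLa cells (Homo sapiens) for antiproliferative activity, read by MTT assay, with a stated time of 48 h (on this read-out lower numbers stand for stronger inhibition and higher numbers for weaker inhibition), compound 1 (`COc1ccc(C(=O)c2ccc3c(c2)C=CC(C)(C)O3)c(NC(=O)CBr)c1`) gives 3050 nM and compound 2 (`C=C(c1cc(OC)c(OC)c(OC)c1)c1ccc(OC)cc1NC(=O)CO`) gives 30 nM as the lower of the two numbers, with a gap beyond the scatter. Compound 3 (`C=C(c1cc(OC)c(OC)c(OC)c1)c1ccc(OC)cc1NC(=O)CNC`) differs from compound 2 by one change: methylamino in place of hydroxy on a saturated chain carbon bound to a carbonyl carbon with methylamino in place of hydroxy on a saturated chain carbon bound to a carbonyl carbon. Among the measured compounds shown here, no measured step covers this change. A modest weakening is expected in this assay and the estimated shift is a 2.3-fold higher number from compound 2 to compound 3 (0.37 log units; beyond the scatter) in the direction of a higher number. Compound 3 is estimated at 70 nM with an expected range from 15 nM to 300 nM in the next measurement.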

Compound 3, half-maximal inhibitory concentration: 140 nM
Compound 3: middle estimate off by 2.0-fold (0.30 log units), on the low side; measured number inside the range.
By their numbers in this assay, from the lowest: compound 2; then compound 3; then compound 1.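

Among the compounds shown here, this is the first single-place comparison: on a saturated chain carbon bound to a carbonyl carbon, methylamino in place of hydroxy weakens inhibition in this assay (a 4.7-fold higher number from compound 2 to compound 3 (0.67 log units; beyond the scatter)). The two groups have the same printed hydrogen-bond donor and acceptor counts, so those counts do not track this step. Nothing measured here accounts for the weakening.

An unsubstituted amine or a methoxy group at this place would separate the effect of the nitrogen from that of the added carbon. On these data alone, how a carboxylic acid or a longer chain would fare here remains open.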